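Notes on a carbamate variant of compound 2

The source may report more compounds than this note shows. Statements on the series, on what has been measured and on what is new or still open speak of the compounds shown alone.

Measured so far:
compound 1 `CC(C)=CCC1Cc2c(OCCCNS(=O)(=O)c3ccc([N+](=O)[O-])cc3)cc(=O)n(CCCO)c2CC1(C)C` gives 17.3%
compound 2 `CC(C)=CCC1Cc2c(OCCCNC(=O)c3cccs3)cc(=O)n(CCCO)c2CC1(C)C` gives 5.6%
compound 3 `CC(C)=CCC1Cc2c(OCCCOc3ccc([N+](=O)[O-])cc3)cc(=O)n(CCCO)c2CC1(C)C` gives 0%

All three numbers come from a functional assay on PANC-1 cells (Homo sapiens) for inhibition, read by MTT assay, with a stated time of 24 h, tested at 10 uM; on this read-out lower numbers stand for less inhibition and higher numbers for more inhibition at the one concentration tested (going by the name of the read-out). Compound 2 stands second highest of the three; its nearest neighbour is compound 3, with a number 5.6 percentage points lower from compound 2 to compound 3 (within the scatter), and its furthest is compound 1, from which a number 11.7 percentage points lower from compound 1 to compound 2 (beyond the scatter).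

Compound 4 `CC(C)=CCC1Cc2c(OC(=O)Nc3ccc(F)c(Cl)c3)cc(=O)n(CCCO)c2CC1(C)C` has not yet been measured. The change from compound 2 is (3-chloro-4-fluorophenyl)carbamoyl in place of 3-(((thiophen-2-yl)carbonyl)amino)propyl on an oxygen on an aromatic ring.

Within the data shown here, two measured steps bear on it, both touching the same oxygen on the aromatic ring. The step from compound 1 to compound 2 swapped only the terminal group on the chain and was modest; the step from compound 2 to compound 3 stayed within the scatter. Neither removed the chain itself, so they guide the expectation only loosely. Given that every number in the series is low, the expected step is a number 2.4 percentage points higher from compound 2 to compound 4 (within the scatter), with no movement beyond the scatter anticipated.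

Compound 4 is therefore estimated at 8%, in a range from 0% to 25%.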

Compound 4, a percentage reported as inhibition, at one concentration (the size of the read-out at that concentration, not a potency): 0%
Compound 4: middle estimate off by 8 percentage points, on the high side; measured number inside the range.
By their numbers in this assay, from the lowest: compounds 3, 4 and 2 (each within the scatter of the next); then compound 1.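

In this assay, putting (3-chloro-4-fluorophenyl)carbamoyl in place of 3-(((thiophen-2-yl)carbonyl)amino)propyl on an oxygen on an aromatic ring gives a number 5.6 percentage points lower from compound 2 to compound 4 (within the scatter). The earlier steps shown here altered only the far end of the chain, whereas this one removes the propyl chain and its amide together, and the reading still stays within the scatter. At this position, then, neither the chain nor the thiophene ring is needed to hold the low reading of compound 2, and the carbamate with its halogenated phenyl ring brings no gain; nothing at hand accounts for this result.

Open, from the compounds shown here alone, is whether the (4-nitrophenyl)sulfonyl group of compound 1 would keep its higher number on a longer chain. Also open, going by these compounds, is whether an amine or a carboxylic acid at the end of the chain would raise the number in this assay.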